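This account rests on a few compounds, and the source may have more. Where it says the series, first, only, none or still open, it means among the compounds named here.

In an ADME assay on MT2 cells (Homo sapiens) for cytotoxicity, read by XTT assay, with a stated time of 4 days (a higher number here means that more compound is tolerated, a lower number that less compound is tolerated), compound 1 `Cc1nc(C(NC(=O)C(=O)Nc2ccc(Cl)cc2)C2CCCN2)sc1CO` gives 45000 nM. Compound 2 `Cc1nc(C(NC(=O)C(=O)Nc2ccc(Cl)cc2)C2CCCCN2)sc1CO` gives > 108000 nM, which is a limit of the assay and not a number. Compound 3 `Cc1nc(C(NC(=O)C(=O)Nc2ccc(Cl)cc2)C2CCCNC2)sc1CO` carries piperidin-3-yl in place of piperidin-2-yl on a saturated chain carbon bound to an amide-type nitrogen and an aromatic carbon. Among the measured compounds shown here, one measured step bears on this change, at the same saturated chain carbon: an at least 2.4-fold higher number from compound 1 to compound 2 (0.38 log units; beyond the scatter), beyond the scatter but resting on that limit. It exchanged the ring rather than moving the attachment, so it is only a loose guide. A modest fall in this assay, perhaps none beyond the scatter, is expected, as the estimated at least 1.3-fold lower number from compound 2 to compound 3 (0.13 log units; that floor lies within the scatter). For compound 3 the expected value is 80000 nM, with an estimated range of 35000 nM to 160000 nM.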

Compound 3, half-maximal cytotoxic concentration: > 81000 nM
Compound 3: only a limit was reported; the forecaster's own chance of this, stated with the estimate: 40%; middle value at least 1.0-fold (0.00 log units) from the limit.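

In this assay compound 3 gives > 81000 nM, a limit and not a number, so piperidin-3-yl on this saturated chain carbon, like piperidin-2-yl, has no measured end point. Exchanging pyrrolidin-2-yl for piperidin-3-yl gives an at least 1.8-fold higher number from compound 1 to compound 3 (0.25 log units; that floor lies within the scatter), so this exchange, unlike the one to piperidin-2-yl, is not shown to exceed the scatter. The step between compound 2 and compound 3 cannot be read, as both rest on limits.

Going by these compounds, whether the two piperidine attachments differ at all remains open. Also open, on these data alone, is how piperidin-4-yl or an open-chain primary amine at this carbon would read.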